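The compounds below may be only part of what the source reports. "The series", "measured", "known", "first", "only" and "open" are said of these compounds alone.

Measured so far in a functional assay on NCI-H630 cells (Homo sapiens) for cytotoxicity, read by sulforhodamine B assay, with a stated time of 5 days; on this read-out lower numbers stand for stronger inhibition and higher numbers for weaker inhibition:
- compound 1 `O=C(CCCCCCCc1ccccc1)N[C@H]1CCOC1=O`: > 100000 nM (a limit)
- compound 2 `O=C(CCCCCCCCCCCc1ccccc1)CC(=O)N[C@H]1CCOC1=O`: 27000 nM
- compound 3 `O=C(CCCc1ccccc1)CC(=O)N[C@H]1CCOC1=O`: > 100000 nM (a limit)

Among the measured compounds shown here, compound 2 is the only compound here with an actual number, 27000 nM. The other two values are limits: the limit of > 100000 nM in this assay, at which 2 of the 3 values shown sit.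

Compound 4 `O=C(CCCCCCCCCc1ccccc1)CC(=O)N[C@H]1CCOC1=O` has phenyl in place of phenethyl on a saturated chain carbon, nine bonds along the chain from a carbonyl carbon. For the measured compounds named here, no measured step covers this change, so the expectation is tentative. It points towards weaker inhibition in this assay. The expectation leans on compound 3, whose value of > 100000 nM is a limit. The expected step is moderate, a 1.7-fold higher number from compound 2 to compound 4 (0.22 log units; within the scatter). For compound 4 the estimate is 45000 nM, with an expected range of 20000 nM to 100000 nM.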

Compound 4, half-maximal inhibitory concentration: 13000 nM
The estimate for compound 4 lay 3.5-fold (0.54 log units) above the measured number; measured number below the stated range.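

In this assay, among the compounds shown here, the change gives the only readable step: a 2.1-fold lower number from compound 2 to compound 4 (0.32 log units; beyond the scatter). At this place, on a saturated chain carbon, nine bonds along the chain from a carbonyl carbon, phenyl in place of phenethyl therefore does not cost inhibition, and the shorter of these two long chains gives the lower number. Compound 1 and compound 3 are limits, and steps to them cannot be read: the limit of > 100000 nM in this assay, at which 2 of the 4 values shown sit.

On these data alone, whether the number falls further at chain lengths between those of compound 3 and compound 4 stays open. Also open, as far as these compounds go, is how a carboxylic acid or an amine in place of the terminal phenyl would read.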